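The source may report more compounds than this note shows. Statements on the series, on what has been measured and on what is new or still open speak of the compounds shown alone.

The measured compounds:

Compound 1, `CSc1nnc(-c2cccc3ccccc23)n1C`, gives > 200 mg/kg in a functional assay on the whole organism for antagonist activity, with Mus musculus as the target (a lower number here means that less compound is needed, a higher number that more compound is needed for the effect), which is a limit of the assay rather than a number.
Compound 2, `Cn1c(-c2cccc3ccccc23)nnc1[S+](C)[O-]`, gives > 200 mg/kg in this assay, again a limit of the assay and not a number.
Among the measured compounds shown here, compound 3, `CSc1nnc(-c2ccccc2F)n1C`, gives 61.3 mg/kg in this assay, the only number among the three.

Compound 1 and compound 2 share a core. The change from compound 1 to compound 2 is a group of 3 heavy atoms (1 carbon, 1 oxygen, 1 sulfur; no ring) in place of a group of 2 heavy atoms (1 carbon, 1 sulfur; no ring), on an aromatic carbon. The step it made, a step that the two limits leave unreadable from compound 1 to compound 2, cannot be read because of the limit of > 200 mg/kg in this assay, at which 2 of the 3 values shown sit.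

Compound 3 carries a different core from compound 1; the difference between the two cores is not broken down here. Compound 4, `Cn1c(-c2ccccc2F)nnc1[S+](C)[O-]`, has not been measured. It differs from compound 3 by a group of 3 heavy atoms (1 carbon, 1 oxygen, 1 sulfur; no ring) in place of a group of 2 heavy atoms (1 carbon, 1 sulfur; no ring), on an aromatic carbon. This is the same kind of change as that from compound 1 to compound 2, not the same one: the two pairs carry different cores, so the change sits in a different surrounding in each pair.

Because the earlier step that the two limits leave unreadable from compound 1 to compound 2 gives no size, there is no measured guide for the new step. The step expected is a 1.2-fold higher number from compound 3 to compound 4 (0.09 log units; within the scatter), a small one, since the starting point is compound 3 at 61.3 mg/kg and the change adds only one oxygen. Compound 4 is expected to give about 75 mg/kg in this assay, most likely between 25 mg/kg and 200 mg/kg.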

Compound 4, dose for half-maximal effect: 57.9 mg/kg
For compound 4 the middle estimate is 1.3-fold (0.11 log units) above the measured one; the range from low to high includes it.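

In this assay the exchange of methylsulfanyl for the oxygen-bearing sulfur group of compound 4, on the core of compound 3, gives a 1.1-fold lower number from compound 3 to compound 4 (0.02 log units; within the scatter) and so leaves the two groups indistinguishable in this read-out on this core. Among the compounds shown here, this is one readable pair on one core, and it shows only that the change can be made here without a step that stands out from the usual spread of repeated measurements; it does not show that the same would hold on any other core. The same change on the core of compound 1 cannot be read, so the two steps cannot be set side by side and nothing can be said about whether the change carries over from one core to the other, and the reason is a limit of the assay and not a number: the limit of > 200 mg/kg in this assay, at which 2 of the 4 values shown sit.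

The compounds shown hold only methylsulfanyl or the oxygen-bearing sulfur group on this aromatic carbon, so it stays open how an amine or a longer chain such as ethylsulfanyl would read at that place. As far as these compounds go, it also stays open how the same exchange would read on a core where both members of the pair give a number.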